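Aryl sulfonate ester variation and cell growth inhibition

The source may hold more compounds than are shown below. What is called first, only, known or untested is meant among the compounds shown, and "the series" means these compounds.

Measured compounds:
Compound 1, `CN1CCN(c2ccc(S(=O)(=O)Oc3cc(Cl)c(Cl)cc3Cl)cc2)C1=O`: 600 nM
Compound 2, `CN1CCN(c2ccc(S(=O)(=O)Oc3ccc(Cl)cc3)cc2)C1=O`: 12000 nM
Compound 3, `CCCN1CCN(c2ccc(S(=O)(=O)Oc3cc(Cl)c(Cl)cc3Cl)cc2)C1=O`: 19000 nM

In a functional assay on HT-29 cells (Homo sapiens) for antiproliferative activity, read by sulforhodamine B assay, with a stated time of 48 h (a lower number here means a stronger inhibitor, a higher number a weaker inhibitor), compound 3 gives the highest of the three numbers. Its nearest neighbour is compound 2, which lies within the scatter of it, while compound 1 lies far below it, the gap being a 32-fold higher number from compound 1 to compound 3 (1.50 log units; beyond the scatter) and that step is large.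

Compound 4, `CCCN1CCN(c2ccc(S(=O)(=O)Oc3ccc(OC)cc3)cc2)C1=O`, has not yet been measured. It differs from compound 3 in one place: 4-methoxyphenyl in place of 2,4,5-trichlorophenyl on an oxygen.

Among the compounds with values here, no measured step changes this aryl group on the same core, so the only guidance is the pair of compound 1 and compound 2, which share the other core and differ in the same aryl group: compound 1 gives 600 nM in this assay, and compound 2 gives 12000 nM. Losing two of the three chlorines there went with a much higher number. Compound 4 removes all three chlorines and brings in a methoxy group instead, so a step to a higher number is expected, a 2.1-fold higher number from compound 3 to compound 4 (0.32 log units; beyond the scatter), though its size is uncertain and the assay may report only a limit.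

Compound 4 is therefore estimated at 40000 nM, with a range from 15000 nM to 120000 nM.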

Compound 4, half-maximal inhibitory concentration: 16000 nM
Estimate against measurement, compound 4: 2.5-fold (0.40 log units) above, and the stated range covers the measured number.
By their numbers in this assay, from the lowest: compound 1; then compounds 2, 4 and 3 (each within the scatter of the next).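

On the core of compound 3, in this assay, putting 4-methoxyphenyl in place of 2,4,5-trichlorophenyl on the oxygen gives a 1.2-fold lower number from compound 3 to compound 4 (0.07 log units; within the scatter) and so leaves the number unmoved, even though all three chlorines are gone and a methoxy group has come in. Within the data shown here, on the core of compound 1 the printed values for a different pair of aryl groups stand apart, since compound 1 with 2,4,5-trichlorophenyl gives 600 nM while compound 2 with 4-chlorophenyl gives 12000 nM, so the weight of this position seems to depend on the rest of the molecule, and on the core of compound 3 the only step beyond the scatter remains the chain change, a 32-fold higher number from compound 1 to compound 3 (1.50 log units; beyond the scatter). No measurement is at hand that accounts for this difference between the two cores.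

Still open, as far as these compounds go, is how 4-methoxyphenyl would fare on the core of compound 1, which would test directly whether the aryl group counts there. Also open, from the compounds shown here alone, is whether an aryl group carrying a carboxylic acid or an amine would stay level with compound 3 and compound 4 on their shared core, and how a longer chain would read on that core.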